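Swapping the ring nitrogen's methyl for a thiazolylcarbonyl

The source may hold more compounds than are shown below. What is called first, only, known or untested is meant among the compounds shown, and "the series" means these compounds.

The shared core of this series is shown by compound 1 `CCCCNc1nc(N)nc2c1CN(C)CC2`, which carries a methyl on an amine nitrogen in a ring. For the measured compounds named here, in an assay on HEK293 cells for agonist activity at Toll-like receptor 8 (Homo sapiens), read by a luciferase reporter, with a stated time of 6 h (on this read-out lower numbers stand for an effect already at smaller amounts and higher numbers for an effect only at larger amounts of compound), compound 1 gives 0.03 uM, the lowest of the three numbers known here. Compound 2 `CCCCNc1nc(N)nc2c1CN(Cc1cc(F)cc(F)c1)CC2` gives 0.23 uM, and compound 3 `CCCCNc1nc(N)nc2c1CN(Cc1ccc(OC(F)(F)F)cc1)CC2` gives 0.24 uM; both replace that methyl with a substituted benzyl, and both sit clearly above compound 1.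

Compound 4 `CCCCNc1nc(N)nc2c1CN(C(=O)c1cscn1)CC2` is not yet measured. It differs from compound 1 as follows: (1,3-thiazol-4-yl)carbonyl in place of methyl on an amine nitrogen in a ring.

Going by the values given here, the one step that bears directly on this change is a 7.7-fold higher number from compound 1 to compound 2 (0.88 log units; beyond the scatter), where a larger group on the same nitrogen raised the number. The values of compound 1 and compound 3 show much the same picture for a different aryl group. Among the compounds with values here, no measured compound carries a carbonyl at this position, so the amide itself is untested. Given that each enlargement at this nitrogen so far has raised the number, a higher number for compound 4 is expected, in a step of about a 6.7-fold higher number from compound 1 to compound 4 (0.82 log units; beyond the scatter). The estimate for compound 4 is therefore 0.2 uM, within a range from 0.05 uM to 0.8 uM.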

Compound 4, minimum effective concentration: 0.5 uM
The estimate for compound 4 lay 2.5-fold (0.40 log units) below the measured number, within the range that was stated.
By their numbers in this assay, from the lowest: compound 1; then compounds 2 and 3 (each within the scatter of the next); then compound 4.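

In this assay, for the compounds shown here, the replacement of methyl with (1,3-thiazol-4-yl)carbonyl gives a 17-fold higher number from compound 1 to compound 4 (1.22 log units; beyond the scatter), the first step at this amine nitrogen in a ring to involve a carbonyl and a larger step than a 7.7-fold higher number from compound 1 to compound 2 (0.88 log units; beyond the scatter). All three groups that replace the methyl raise the number, and none of the compounds shown goes against this, so the methyl of compound 1 remains the group with the lowest number at this position. The change still leaves a measurable effect, with compound 4 at 0.5 uM, so an amide at this nitrogen does not abolish the read-out, although nothing available explains the size of the rise.

The compounds shown leave open whether the rise belongs to the carbonyl or to the thiazole ring: a (1,3-thiazol-4-yl)methyl group and a benzoyl group would separate the two. They also leave open how the number responds to groups smaller than these, such as a plain hydrogen on this nitrogen, an ethyl group or an acetyl group.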